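Amino for Methoxy in a Topoisomerase Inhibition Series

The source may hold more compounds than are shown below. What is called first, only, known or untested is meant among the compounds shown, and "the series" means these compounds.

Compound 2 `COc1cc(OC)cc(-c2cc3ccccc3c(-c3cccc(OC)c3)n2)c1` shows no measurable effect in an assay on isolated protein for inhibition of DNA topoisomerase 1 (Homo sapiens), with a stated time of 30 min, tested at 100 uM (on this read-out higher numbers stand for a stronger effect at the one concentration tested and lower numbers for a weaker effect), where compound 2 gives 0%. Its nearest neighbour, compound 1 `COc1cc(OC)cc(-c2cc3ccccc3c(-c3cccc(O)c3)n2)c1`, carries hydrogen on the oxygen where compound 2 carries methyl; in this assay compound 1 gives 0%, and the step of no change at the digits printed from compound 1 to compound 2 (within the scatter) lies within the scatter. The next compound, compound 3 `COc1cc(OC)cc(-c2cc3ccccc3c(-c3cccc(N)c3)n2)c1`, differs from compound 2 in a single place: amino in place of methoxy on an aromatic carbon. Going by the values given here, only one measured step touches the same place, the one from compound 1 to compound 2, and it was flat; it exchanged groups bound through oxygen, whereas the new change brings in a nitrogen-bearing group, so it is only a loose guide. With both measured compounds inactive and the step of no change at the digits printed from compound 1 to compound 2 (within the scatter) flat, the expected step of a number 3 percentage points higher from compound 2 to compound 3 (within the scatter) is none beyond the scatter. Compound 3 is therefore estimated at 3%, with a likely range from 0% to 15%.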

Compound 3, a percentage reported as inhibition, at one concentration (the size of the read-out at that concentration, not a potency): 0%
The estimate for compound 3 lay 3 percentage points above the measured number; measured number inside the range.
By their numbers in this assay, from the lowest: compounds 1, 2 and 3 (each within the scatter of the next).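

In this assay, amino, which carries a hydrogen-bond donor that methoxy lacks, still gives no change at the digits printed from compound 2 to compound 3 (within the scatter), and amino in place of hydroxy gives no change at the digits printed from compound 1 to compound 3 (within the scatter). A nitrogen-bearing group at this ring position therefore reads the same as the two groups bound through oxygen, so none of the three can be ranked above another. Nothing available explains why this position shows no response to these changes.

On these data alone, what remains open is whether a larger or differently charged group on this same carbon, such as a carboxylic acid, an acetamide or a longer chain like butoxy, would give any measurable inhibition. The three compounds also share the rest of the core, so they cannot show whether changes elsewhere, such as replacing the two methoxy groups on the other aromatic ring, would matter.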